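The compounds below may be only part of what the source reports. "The series", "measured", "known", "first", "only" and "open" are said of these compounds alone.

In an ADME assay on L02 cells (Homo sapiens) for inhibition, read by CCK-8 assay, with a stated time of 48 h (on this read-out lower numbers stand for stronger inhibition of growth and higher numbers for weaker inhibition of growth), three compounds sharing one core have been measured. Compound 1 `Cc1ccccc1Nc1nc(NC2CCCCC2)ncc1Cl`, with cyclohexyl on a nitrogen, gives > 100000 nM, which is a limit and not a number. Compound 2 `Cc1ccccc1Nc1nc(Nc2ccccc2)ncc1Cl`, with phenyl in that place, gives > 100000 nM, also a limit. Compound 3 `Cc1ccccc1Nc1nc(NCc2ccccc2)ncc1Cl`, with benzyl there, gives > 100000 nM, again a limit. Going by the values given here, compound 2 therefore has no exact value, and the series so far shows only (the limit of > 100000 nM in this assay, at which 3 of the 3 values shown sit).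

Compound 4 `CCN1CCN(c2ccc(Nc3ncc(Cl)c(Nc4ccccc4C)n3)cc2)CC1` differs from compound 2 by one change: 4-ethylpiperazin-1-yl in place of hydrogen on an aromatic carbon. The measured steps are a step that the two limits leave unreadable from compound 1 to compound 2, a step that the two limits leave unreadable from compound 1 to compound 3 and a step that the two limits leave unreadable from compound 2 to compound 3. None has a readable size, and each swaps the group on the nitrogen instead of adding 4-ethylpiperazin-1-yl, so they offer little guidance.

Among the compounds with values here, compound 2 stands at the limit > 100000 nM, so the only readable step from it is toward stronger inhibition of growth. That direction is expected in this assay, though its size is uncertain. The expected step is an at least 3.3-fold lower number from compound 2 to compound 4 (0.52 log units; beyond the scatter). For compound 4 the estimated value is 30000 nM, with an expected range of 5000 nM to 100000 nM.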

Compound 4, concentration for 50% growth inhibition: 970 nM
Estimate against measurement, compound 4: 31-fold (1.49 log units) above, outside the stated range (below it).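

In this assay, 4-ethylpiperazin-1-yl in place of hydrogen on an aromatic carbon, para to a large group, brings an at least 100-fold lower number from compound 2 to compound 4 (2.01 log units; beyond the scatter), a large step beyond the scatter. Going by these compounds alone, the steps among compound 1, compound 2 and compound 3 cannot be read, so this is the first change with a readable effect on inhibition of growth, and it shows that this ring position can respond strongly to substitution. Compound 4 is also the only compound here with an exact value, which leaves it without a measured neighbour of similar strength: the limit of > 100000 nM in this assay, at which 3 of the 4 values shown sit.

With only this one substituent at this position, the compounds shown leave open whether the whole 4-ethylpiperazin-1-yl group is needed for the step. A morpholine ring or a piperazine without the ethyl group would help to separate the parts of the group, and the same group on compound 1 or compound 3 would test whether the step carries over.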